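From 4-chlorobenzyl to 2-nitrobenzyl

This account rests on a few compounds, and the source may have more. Where it says the series, first, only, none or still open, it means among the compounds named here.

- compound 1 `Clc1ccc(COc2ccc(OCCOCCNC3CCCCC3)cc2)cc1` (2690 nM)
- compound 2 `c1ccc(COc2ccc(COc3ccc(OCCOCCNC4CCCCC4)cc3)cc2)cc1` (4350 nM)

In a functional assay on HCT-116 cells (Homo sapiens) for inhibition, read by CCK-8 assay, with a stated time of 70 h (on this read-out lower numbers stand for stronger inhibition and higher numbers for weaker inhibition), compound 1 has only compound 2 for comparison, and the two values lie within the scatter of each other. For the measured compounds named here, compound 3 `O=[N+]([O-])c1ccccc1COc1ccc(OCCOCCNC2CCCCC2)cc1` carries a different change (2-nitrophenyl in place of 4-chlorophenyl on a saturated chain carbon bound to an oxygen on an aromatic ring) that no measured compound covers directly. Going by the values given here, the one measured step is a 1.6-fold higher number from compound 1 to compound 2 (0.21 log units; within the scatter) and it alone bears on this change, so no step beyond the scatter is expected in this assay in either direction. The estimate amounts to a 1.2-fold higher number from compound 1 to compound 3 (0.08 log units; within the scatter) as the expected step. Compound 3 is thus estimated at 3200 nM (range 1300 nM to 7500 nM).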

Compound 3, half-maximal inhibitory concentration: 11100 nM
Compound 3: middle estimate off by 3.5-fold (0.54 log units), on the low side; the whole stated range lies below it.
By their numbers in this assay, from the lowest: compounds 1 and 2 (each within the scatter of the next); then compound 3.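

Putting 2-nitrophenyl in place of 4-chlorophenyl on a saturated chain carbon bound to an oxygen on an aromatic ring gives, in this assay (a 4.1-fold higher number from compound 1 to compound 3 (0.62 log units; beyond the scatter)), the first step beyond the scatter among these compounds. The benzyloxy change (a 1.6-fold higher number from compound 1 to compound 2 (0.21 log units; within the scatter)) stayed within it, so the groups on this part of compound 1 are not all interchangeable. No evidence at hand bears on the reason.

The compounds shown leave open whether the nitro group or its ring place matters more: the group and its place change together. A 2-chlorophenyl or a 4-nitrophenyl group here would separate the two.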